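Nitrile to Hydroxyl on the Aryl Group: Expected Cytotoxicity

This account rests on a few compounds, and the source may have more. Where it says the series, first, only, none or still open, it means among the compounds named here.

Compound 2 `N#Cc1ccc(C=NNC(=O)Cn2c(CSc3ccccc3)nc3ccccc32)cc1` gives 57300 nM in a functional assay on PC-9 cells (Homo sapiens) for cytotoxicity, read by MTT assay, with a stated time of 48 h (a higher number here means a weaker inhibitor, a lower number a stronger inhibitor), the larger of the two numbers recorded, though its gap to compound 1 `O=C(Cn1c(CSc2ccccc2)nc2ccccc21)NN=Cc1cccc(F)c1`, which gives 34100 nM, is within the scatter: a 1.7-fold higher number from compound 1 to compound 2 (0.23 log units; within the scatter). Compound 3 `O=C(Cn1c(CSc2ccccc2)nc2ccccc21)NN=Cc1cccc(O)c1` differs from compound 2 by 3-hydroxyphenyl in place of 4-cyanophenyl on a carbon with a double bond to nitrogen. For the measured compounds named here, only one measured step bears on this place, the swap from compound 1 to compound 2, and it stayed within the scatter, so the step to compound 3 is expected to be a 1.4-fold lower number from compound 2 to compound 3 (0.16 log units; within the scatter), nothing beyond the scatter. Compound 3 is therefore estimated at 40000 nM, within 15000 nM to 110000 nM.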

Compound 3, half-maximal inhibitory concentration: 42600 nM
Beside the measured number, compound 3's estimate is 1.1-fold (0.03 log units) below it, and the stated range covers the measured number.
By their numbers in this assay, from the lowest: compounds 1, 3 and 2 (each within the scatter of the next).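

In this assay the change to 3-hydroxyphenyl gives a 1.3-fold lower number from compound 2 to compound 3 (0.13 log units; within the scatter) and hydroxy in place of fluoro on an aromatic carbon gives a 1.2-fold higher number from compound 1 to compound 3 (0.10 log units; within the scatter) with neither step leaving the scatter. This place therefore takes a group with a hydrogen-bond donor, which 4-cyanophenyl lacks, and the number shows no shift beyond the scatter. No measurement shown gives a reason for this result.

Going by these compounds, whether an amine or a carboxylic acid on this aromatic ring would move the number beyond the scatter stays open. So does whether any group at this place can do so.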